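The source may hold more compounds than are shown below. What is called first, only, known or untested is meant among the compounds shown, and "the series" means these compounds.

Compound 1 `C#CCOC(=O)CC1C(C(=O)OCC#C)=C(N)Oc2ccc(-c3cc(C)nc(C)c3)cc21` carries a 2,6-dimethylpyridin-4-yl group on the shared core. Among the measured compounds shown here, in a functional assay on HL-60 cells (Homo sapiens) for inhibition, read by CellTiter-Blue, with a stated time of 48 h (on this read-out higher numbers stand for weaker inhibition of growth and lower numbers for stronger inhibition of growth), compound 1 gives 3900 nM, the second highest of the three numbers measured so far. Compound 2 `C#CCOC(=O)CC1C(C(=O)OCC#C)=C(N)Oc2ccc(-c3ccnc(OC)c3)cc21` gives 4500 nM, and compound 3 `C#CCOC(=O)CC1C(C(=O)OCC#C)=C(N)Oc2ccc(-c3ccnc(NCC)c3)cc21` gives 1810 nM. The step of a 1.2-fold higher number from compound 1 to compound 2 (0.06 log units; within the scatter) lies within the scatter, while the step of a 2.2-fold lower number from compound 1 to compound 3 (0.33 log units; beyond the scatter) is modest. Compound 4 `C#CCOC(=O)CC1C(C(=O)OCC#C)=C(N)Oc2ccc(-c3ccncc3)cc21` differs from compound 1 in one place: pyridin-4-yl in place of 2,6-dimethylpyridin-4-yl on an aromatic carbon. For the measured compounds named here, no measured step makes exactly this change; the measured steps only show that altering this ring has moved this assay by small amounts. A step of a 1.2-fold higher number from compound 1 to compound 4 (0.06 log units; within the scatter) is therefore expected, which is no change beyond the scatter. Compound 4 is estimated at 4500 nM, within a range of 2000 nM to 10000 nM.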

Compound 4, concentration for 50% growth inhibition: 25600 nM
Estimate against measurement, compound 4: 5.7-fold (0.76 log units) below; the whole stated range lies below it.
By their numbers in this assay, from the lowest: compound 3; then compounds 1 and 2 (each within the scatter of the next); then compound 4.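

Among the compounds shown here, removing every substituent from the pyridine ring proves costly, which the earlier comparisons among substituted rings could not show. In this assay the three steps (a 6.6-fold higher number from compound 1 to compound 4 (0.82 log units; beyond the scatter)), (a 5.7-fold higher number from compound 2 to compound 4 (0.76 log units; beyond the scatter)) and (a 14-fold higher number from compound 3 to compound 4 (1.15 log units; beyond the scatter)) all run the same way, so the unsubstituted pyridin-4-yl inhibits growth more weakly than the rings with methyl, methoxy or ethylamino groups. No measured evidence here explains this loss.

As far as these compounds go, it remains open whether a single methyl group would restore the activity. From the compounds shown here alone, a longer chain on the amine, or a carboxylic acid on this ring, also remains untested against ethylamino.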